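The source may hold more compounds than are shown below. What is called first, only, known or untested is meant among the compounds shown, and "the series" means these compounds.

Working notes on the series.

Compound 1 `Cc1cc(C)c(S(=O)(=O)N2CCC(N3CCC(CCO)CC3)CC2)c(C)c1` is read in an ADME assay on HCT-116 cells (Homo sapiens) for cytotoxicity, read by CellTiter-Glo, with a stated time of 72 h; on this read-out lower numbers stand for stronger inhibition and higher numbers for weaker inhibition. In this assay compound 1 gives > 5000 nM, which is a limit of the assay rather than a number. Compound 2 `Cc1cc(C)c(S(=O)(=O)N2CCC(N3CCC(Cc4ccccc4F)CC3)CC2)c(C)c1` carries 2-fluorophenyl in place of hydroxymethyl on a saturated chain carbon bound to a saturated ring carbon. In this assay compound 2 gives > 5000 nM, again a limit. The step that the two limits leave unreadable from compound 1 to compound 2 cannot be read from the two limits. Both values sit at the same limit (the limit of > 5000 nM in this assay, at which 2 of the 2 values shown sit), so compound 1 stands at that limit, with no numbered value anywhere in the series to place it against.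

Compound 3 `Cc1cc(C)c(S(=O)(=O)N2CCC(C3OCC(C)CO3)CC2)c(C)c1` has not yet been measured in this assay. It differs from compound 1 by a group of 7 heavy atoms (5 carbon, 2 oxygen; one six-membered non-aromatic ring with 2 hetero atoms) in place of a group of 9 heavy atoms (7 carbon, 1 nitrogen, 1 oxygen; one six-membered non-aromatic ring with 1 hetero atom), on a saturated ring carbon. Within the data shown here, no measured step bears on this change, since the only measured step is unreadable. Among the measured compounds shown here, the two limits so far give no sign of any compound reaching a number. Compound 3 is therefore expected to behave alike, with an expected step that the limit leaves unreadable from compound 1 to compound 3, nothing beyond the scatter. For compound 3 the estimate in this assay is 9000 nM, with a range from 3000 nM to 30000 nM, most probably reported only as a limit.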

Compound 3, half-maximal inhibitory concentration: > 5000 nM
Compound 3 ended at the assay's limit; the forecaster's own chance of this, stated with the estimate: 85%; the middle value is on the limit's open side.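

No step can be read from compound 1 to compound 3 in this assay, since both values are limits of the assay and not numbers: the limit of > 5000 nM in this assay, at which 3 of the 3 values shown sit.

The compounds shown leave open whether any change on the shared core gives a numbered value in this assay, and how large any step between them would be.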